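The source may report more compounds than this note shows. Statements on the series, on what has been measured and on what is new or still open speak of the compounds shown alone.

Compound 1 `COc1c(F)c(N)c2c(=O)cc(-c3ccc(N)c(F)c3)oc2c1F` — 34000 nM in a functional assay on HeLa cells (Homo sapiens) for cytotoxicity, read by neutral red uptake, with a stated time of 3 days; on this read-out lower numbers stand for stronger inhibition and higher numbers for weaker inhibition
Compound 2 `Nc1ccc(-c2cc(=O)c3c(N)c(F)c(CO)c(F)c3o2)cc1F` — 24000 nM
Compound 3 `CN(C)CC(=O)OCc1c(F)c(N)c2c(=O)cc(-c3ccc(N)c(F)c3)oc2c1F` — 9200 nM

Compound 2 stands at the second highest of the three numbers in this assay: against compound 1 the step is a 1.4-fold lower number from compound 1 to compound 2 (0.15 log units; within the scatter), against compound 3 it is a 2.6-fold lower number from compound 2 to compound 3 (0.42 log units; beyond the scatter). Compound 4 `CN(C)Cc1c(F)c(N)c2c(=O)cc(-c3ccc(N)c(F)c3)oc2c1F` has not been measured. The change from compound 2 is dimethylamino in place of hydroxy on a saturated chain carbon bound to an aromatic carbon. Among the compounds with values here, the steps that bear on it are a 2.6-fold lower number from compound 2 to compound 3 (0.42 log units; beyond the scatter), where a dimethylamino-bearing group likewise enters at the hydroxymethyl oxygen, and a 3.7-fold lower number from compound 1 to compound 3 (0.57 log units; beyond the scatter); both are modest lowerings, whereas the step between compound 1 and compound 2 stays within the scatter. A modest lowering of similar size is therefore expected for compound 4, a 2.2-fold lower number from compound 2 to compound 4 (0.34 log units; beyond the scatter). Compound 4 is estimated at 11000 nM, within 5000 nM to 25000 nM.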

Compound 4, half-maximal inhibitory concentration: 8900 nM
Compound 4: the middle estimate sits 1.2-fold (0.09 log units) above what was measured; low and high end bracket the measured number.
By their numbers in this assay, from the lowest: compounds 4 and 3 (each within the scatter of the next); then compounds 2 and 1 (each within the scatter of the next).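

In this assay, dimethylamino placed directly on the saturated chain carbon in compound 4 lowers the number relative to the hydroxy of compound 2 (a 2.7-fold lower number from compound 2 to compound 4 (0.43 log units; beyond the scatter)) and relative to compound 1 (a 3.8-fold lower number from compound 1 to compound 4 (0.58 log units; beyond the scatter)). The lowering therefore does not require the longer (((dimethylamino)methyl)carbonyl)oxy group, since compound 3 and compound 4 stand level (a 1.0-fold lower number from compound 3 to compound 4 (0.01 log units; within the scatter)). No measurement at hand explains these numbers.

As far as these compounds go, whether the lowering is specific to dimethylamino remains open. A primary amine, a pyrrolidine or a carboxylic acid on the same carbon would test this.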